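Nucleoside series: furan-3-yl to 1-benzofuran-2-yl exchange

The source may report more compounds than this note shows. Statements on the series, on what has been measured and on what is new or still open speak of the compounds shown alone.

Measured compounds in a functional assay on A549 cells (Homo sapiens), read by MTT assay, with a stated time of 72 h; a higher number here means a weaker inhibitor, a lower number a stronger inhibitor:
Compound 1 `COc1ncnc2c1c(-c1ccoc1)cn2[C@@H]1O[C@H](CO)[C@@H](O)[C@H]1O`: 1160 nM
Compound 2 `CN(C)c1ncnc2c1c(-c1ccoc1)cn2[C@@H]1O[C@H](CO)[C@@H](O)[C@H]1O`: > 20000 nM (a limit)

Within the data shown here, compound 1 gives 1160 nM in this assay and is the only compound of the set with a measured number. Compound 2 reaches > 20000 nM in this assay, which is a limit of the assay and not a number (the limit of > 20000 nM in this assay, at which 1 of the 2 values shown sits). Among the measured compounds shown here, the one measured step, an at least 17-fold higher number from compound 1 to compound 2 (1.23 log units; beyond the scatter), is a dimethylamino in place of methoxy on an aromatic carbon of the shared core; it leaves the furan-3-yl group untouched. Compound 3 `COc1ncnc2c1c(-c1cc3ccccc3o1)cn2[C@@H]1O[C@H](CO)[C@@H](O)[C@H]1O` differs from compound 1 at that other position: 1-benzofuran-2-yl in place of furan-3-yl on an aromatic carbon. For the measured compounds named here, no measured step touches this position, so neither direction nor size of the step can be read from the data. A moderate weakening is expected for compound 3, a 2.2-fold higher number from compound 1 to compound 3 (0.33 log units; beyond the scatter), with wide uncertainty. The estimate for compound 3 in this assay is 2500 nM, ranging from 600 nM to 12000 nM.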

Compound 3, half-maximal inhibitory concentration: 17700 nM
The estimate for compound 3 lay 7.1-fold (0.85 log units) below the measured number, outside the stated range (above it).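

In this assay, the position carrying furan-3-yl proves sensitive to change: 1-benzofuran-2-yl in place of furan-3-yl gives a 15-fold higher number from compound 1 to compound 3 (1.18 log units; beyond the scatter), with the methoxy group of the shared core left in place. Extending the five-membered aromatic ring with a six-membered aromatic ring of carbon only is therefore not tolerated here, and compound 1 stands as the strongest inhibitor of the three. Compound 2 stays a limit and not a number, so the size of its step cannot be ranked against this one: the limit of > 20000 nM in this assay, at which 1 of the 3 values shown sits.

On these data alone, it remains open whether the loss follows the added ring or the changed point of attachment, a question furan-2-yl at this place would separate. As far as these compounds go, how a simple phenyl ring or a small methyl group behaves at this position is also open.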